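An Unsaturated Chain Moved onto a Second Core

This account rests on a few compounds, and the source may have more. Where it says the series, first, only, none or still open, it means among the compounds named here.

Of the compounds shown here, three have so far been measured in a functional assay on HT-29 cells (Homo sapiens) for cytotoxicity, read by XTT assay, with a stated time of 72 h; on this read-out lower numbers stand for stronger inhibition and higher numbers for weaker inhibition. Compound 1 `CCCCCCCCCCCCCCCCCCc1c(O)cc(O)c(C(C)=O)c1O` gives 28000 nM. Compound 2 `CCCCCCCC/C=C\CCCCCCCCOc1cc(O)cc(O)c1C(C)=O` gives 31000 nM, and these two numbers lie within the scatter of each other. Compound 3 `CCCCCCCCCCCCCCCCCCOc1cc(O)cc(O)c1C(C)=O` reaches only a limit of this assay, > 100000 nM, which is not a number.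

Between the two measured compounds that share a core, an at least 3.2-fold lower number from compound 3 to compound 2 (0.50 log units; beyond the scatter), the change being (dec-1-en-1-yl in place of decyl on a saturated chain carbon, eight bonds along the chain from an oxygen on an aromatic ring). How the core of compound 1 differs from the core of compound 3 is not broken down here.

Compound 4 `CCCCCCCC/C=C\CCCCCCCCc1c(O)cc(O)c(C(C)=O)c1O` is not yet measured. It differs from compound 1 by dec-1-en-1-yl in place of decyl on a saturated chain carbon, eight bonds along the chain from an aromatic carbon, the same kind of change, though here the chain sits eight bonds from an aromatic carbon rather than from an oxygen on an aromatic ring. The earlier step, an at least 3.2-fold lower number from compound 3 to compound 2 (0.50 log units; beyond the scatter), is the basis of the expectation. Compound 4 is therefore expected to give about 15000 nM, an estimated step of a 1.9-fold lower number from compound 1 to compound 4 (0.27 log units; within the scatter).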

Compound 4, half-maximal inhibitory concentration: > 100000 nM
Compound 4: no number, only a limit; the forecaster's own chance of this, stated with the estimate: 3%; at least 6.6-fold (0.82 log units) between middle value and limit.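

The change did not carry from one core to the other: on the core of compound 1, dec-1-en-1-yl in place of decyl gives an at least 3.5-fold higher number from compound 1 to compound 4 (0.55 log units; beyond the scatter), the opposite direction to the earlier step. The two steps differ clearly: the same change on two cores in this assay, an at least 3.2-fold lower number (0.50 log units; beyond the scatter) from compound 3 to compound 2 and an at least 3.5-fold higher number (0.55 log units; beyond the scatter) from compound 1 to compound 4, at least 11-fold (1.06 log units) apart, beyond the scatter of two such steps. Each step rests on a limit of the assay, so only its smallest possible size is known, and nothing here shows why the two cores differ: the limit of > 100000 nM in this assay, at which 2 of the 4 values shown sit.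

The compounds shown leave open how a shorter chain would behave on either core. They also leave open whether an amine or a carboxylic acid in place of the chain would give a number in this assay.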